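The source may hold more compounds than are shown below. What is called first, only, known or untested is meant among the compounds shown, and "the series" means these compounds.

Measured in an assay on isolated protein for binding affinity to sphingosine 1-phosphate receptor 2 (Homo sapiens), read by surface plasmon resonance; a lower number here means tighter binding, a higher number weaker binding:

Compound 1 `Cc1nn(C)c2nc(NNC(=O)Nc3cc(Cl)nc(Cl)c3)cc(-c3ccc(F)cc3)c12` gives 980 nM
Compound 2 `CCCc1cc(NNC(=O)Nc2cc(Cl)nc(Cl)c2)nc2c1c(C)nn2C` gives 2360 nM
Compound 3 `Cc1cc(NNC(=O)Nc2cc(Cl)nc(Cl)c2)nc2c1c(C)nn2C` gives 11000 nM

Compound 3 stands at the highest number of the three in this assay; its nearest neighbour is compound 2, with a 4.7-fold higher number from compound 2 to compound 3 (0.67 log units; beyond the scatter), and the furthest is compound 1, with an 11-fold higher number from compound 1 to compound 3 (1.05 log units; beyond the scatter). Compound 4 `Cc1nn(C)c2nc(NNC(=O)Nc3cc(Cl)nc(Cl)c3)cc(C3CCCCC3)c12` differs from compound 3 in one place: cyclohexyl in place of methyl on an aromatic carbon.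

Two of the measured steps bear on this change, since both alter what sits on the same aromatic carbon. The step from the 4-fluorophenyl compound to the methyl compound was large, an 11-fold higher number from compound 1 to compound 3 (1.05 log units; beyond the scatter), and the step from the propyl compound to the methyl compound was modest, a 4.7-fold higher number from compound 2 to compound 3 (0.67 log units; beyond the scatter). Both point the same way: a larger group on that carbon goes with a lower number, a smaller group with a higher one. Cyclohexyl is the larger group here, so compound 4 is expected to come in well below compound 3, plausibly between compound 2 and compound 1, that is a 7.3-fold lower number from compound 3 to compound 4 (0.87 log units; beyond the scatter). The estimate for compound 4 in this assay is therefore 1500 nM, with a range from 500 nM to 5000 nM.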

Compound 4, dissociation constant: 2010 nM
Estimate against measurement, compound 4: 1.3-fold (0.13 log units) below; the range from low to high includes it.
By their numbers in this assay, from the lowest: compound 1; then compounds 4 and 2 (each within the scatter of the next); then compound 3.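

In this assay, cyclohexyl on this aromatic carbon, opposite the ring nitrogen, reads well apart from methyl, a 5.5-fold lower number from compound 3 to compound 4 (0.74 log units; beyond the scatter), so the link between a larger group and a lower number, seen earlier with propyl and 4-fluorophenyl, extends in these compounds to a non-aromatic ring of carbon only. That link does not run on through the whole series, however: cyclohexyl and propyl cannot be told apart, a 1.2-fold lower number from compound 2 to compound 4 (0.07 log units; within the scatter), so closing the substituent into a saturated ring gives no measurable separation from the open chain, whereas 4-fluorophenyl remains distinct from cyclohexyl, a 2.1-fold higher number from compound 1 to compound 4 (0.31 log units; beyond the scatter), and compound 1 holds the lowest number of the four. Nothing available here offers an explanation for these differences.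

The compounds shown leave open whether the aromatic ring or its fluorine sets compound 1 apart, a question that an unsubstituted phenyl group on the same carbon would help to settle. They also leave open how a longer chain, or a cyclohexyl ring carrying an amine, would read at this position.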